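Tert-Butoxycarbonyl in Place of Tert-Butyl: Estimating Compound 4

The source may hold more compounds than are shown below. What is called first, only, known or untested is meant among the compounds shown, and "the series" means these compounds.

Three measured compounds share one core and differ only in the group attached to a carbonyl carbon. Compound 1 `COc1cccc(-c2nc(SC)nc3sc(C(=O)NCc4ccccc4)c(N)c23)c1` carries benzylamino there, compound 2 `CCOC(=O)c1sc2nc(SC)nc(-c3cccc(OC)c3)c2c1N` carries ethoxy, and compound 3 `COc1cccc(-c2nc(SC)nc3sc(C(=O)NNC(C)(C)C)c(N)c23)c1` carries a (tert-butyl)amino group on an amide-type nitrogen. In a functional assay on HEK293 cells for agonist activity at lutropin-choriogonadotropic hormone receptor (Homo sapiens), read by cAMP accumulation (a higher number here means a larger maximal response, a lower number a smaller maximal response), compound 1 gives 7.8%, compound 2 gives 4.2% and compound 3 gives 6%. Compound 3 stands second highest of these three numbers, yet all three sit within the scatter of one another, so none can be called stronger than another.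

Compound 4 `COc1cccc(-c2nc(SC)nc3sc(C(=O)NNC(=O)OC(C)(C)C)c(N)c23)c1` arises from compound 3 by one change: tert-butoxycarbonyl in place of tert-butyl on an amine nitrogen. The measured steps that touch this same end of the molecule are small: a number 1.8 percentage points lower from compound 1 to compound 3 (within the scatter) and a number 1.8 percentage points higher from compound 2 to compound 3 (within the scatter), and likewise a number 3.6 percentage points lower from compound 1 to compound 2 (within the scatter). Every variation tried at this position has left the read-out in this assay within the scatter, and nothing in these data points to a different outcome for a tert-butoxycarbonyl group. The expected step is therefore no change at the digits printed from compound 3 to compound 4 (within the scatter), essentially no change beyond the scatter. Compound 4 is expected to reach about 6% in this assay, with a range from 1% to 14%.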

Compound 4, largest response reached (reported as efficacy), in percent of the reference or control that the assay uses: 2.4%
Beside the measured number, compound 4's estimate is 3.6 percentage points above it, within the range that was stated.
By their numbers in this assay, from the lowest: compounds 4, 2, 3 and 1 (each within the scatter of the next).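

Tert-butoxycarbonyl has more heavy atoms than tert-butyl and brings hydrogen-bond acceptors where tert-butyl has none, yet in this assay the swap gives a number 3.6 percentage points lower from compound 3 to compound 4 (within the scatter) and cannot be told apart from no change. The comparisons with the other two groups read the same way, with a number 1.8 percentage points lower from compound 2 to compound 4 (within the scatter) and a number 5.4 percentage points lower from compound 1 to compound 4 (within the scatter), so the widest gap among these four compounds still does not clear the scatter, and they cannot be put in any order at this end of the molecule. No measurement here offers an explanation for these numbers.

The compounds shown leave open whether a carboxylic acid, or an amine at the end of a longer chain, attached to the same carbonyl carbon would give a response in this assay that stands clear of the scatter. They also leave open whether any group at this end can do so on its own, or whether a change elsewhere on the shared core, which stays the same in all four compounds, would be needed.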